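Moving the Hydroxyl Group on the Anilide Ring

This account rests on a few compounds, and the source may have more. Where it says the series, first, only, none or still open, it means among the compounds named here.

Measured in a functional assay on A549 cells (Homo sapiens) for cytotoxicity, read by CCK-8 assay; a lower number here means a stronger inhibitor, a higher number a weaker inhibitor:
- Compound 1 `O=C(Nc1ccc(O)cc1)c1ncc(-c2ccc(F)cc2)o1`: > 30000 nM, a limit of the assay
- Compound 2 `O=C(Nc1ccc(O)cc1)c1ncc(-c2ccccc2)o1`: 1080 nM

Going by the values given here, compound 2 holds the only true number so far, 1080 nM. Compound 3 `O=C(Nc1cccc(O)c1)c1ncc(-c2ccccc2)o1` differs from it at one place: 3-hydroxyphenyl in place of 4-hydroxyphenyl on an amide-type nitrogen. Among the compounds with values here, the one measured step, an at least 27-fold lower number from compound 1 to compound 2 (1.44 log units; beyond the scatter), is large, but it lies elsewhere in the structure and gives no direct guide to this change. A moderate step toward a higher number is therefore expected in this assay, though the direction is uncertain. For compound 3 the estimated value is 2000 nM, with an expected range of 500 nM to 10000 nM. This estimate means an expected 1.9-fold higher number from compound 2 to compound 3 (0.27 log units; within the scatter).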

Compound 3, half-maximal inhibitory concentration: > 30000 nM
Compound 3 ended at the assay's limit (the forecaster's own chance of this, stated with the estimate: 20%); at least 15-fold (1.17 log units) between middle value and limit.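

In this assay, the hydroxyl position on the anilide ring proves sensitive: replacing 4-hydroxyphenyl with 3-hydroxyphenyl on the amide-type nitrogen gives an at least 27-fold higher number from compound 2 to compound 3 (1.44 log units; beyond the scatter), although the two groups have the same atoms. Compound 3 stands at > 30000 nM, which is a limit of the assay, so the full size of this step stays unknown: the limit of > 30000 nM in this assay, at which 2 of the 3 values shown sit.

From the compounds shown here alone, whether a methoxy group or an amine in place of the hydroxyl would retain the value of compound 2 remains open. So does whether the hydroxyl is needed on this ring at all.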